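The source may report more compounds than this note shows. Statements on the series, on what has been measured and on what is new or still open speak of the compounds shown alone.

Compound 1, `O=C(O)c1ccc(COc2ccc(/C=C3\SC(=S)N(c4ccc([N+](=O)[O-])cc4)C3=O)cc2)cc1`, in an assay on isolated protein for inhibition of Apoptosis regulator Bcl-2 (Homo sapiens), read by fluorescence polarization (a higher number here means a weaker inhibitor, a lower number a stronger inhibitor), gives only a limit, > 10000 nM.
Compound 2, `Cc1cccc(N2C(=O)/C(=C/c3ccc(OCc4ccc(C(=O)O)cc4)cc3)SC2=S)c1`, gives in this assay only a limit, > 10000 nM.
Compound 3, `O=C(O)c1ccc(COc2ccc(/C=C3\SC(=S)N(c4cccc(C(F)(F)F)c4)C3=O)cc2)cc1`, gives in this assay only a limit, > 10000 nM.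

Compound 3 therefore stands where every value of this set stands: at the limit of > 10000 nM in this assay, at which 3 of the 3 values shown sit. None of the three measured steps can be read, since each joins two limits: a step that the two limits leave unreadable from compound 1 to compound 2, a step that the two limits leave unreadable from compound 1 to compound 3 and a step that the two limits leave unreadable from compound 2 to compound 3. Across a nitro, a methyl and a trifluoromethyl substituent on the aryl ring carried by the ring nitrogen, no compound has yet produced a number.

Compound 4, `O=C(O)c1ccc(COc2ccc(/C=C3\SC(=S)N(c4ccc(Cl)cc4)C3=O)cc2)cc1`, is not yet measured. It differs from compound 3 in one place: 4-chlorophenyl in place of 3-(trifluoromethyl)phenyl on an amide-type nitrogen in a ring. The measured steps bear on this change only in that the aryl group on the same ring nitrogen has been varied in each of compounds 1, 2 and 3 without a readable value appearing. Nothing in the data gives reason to expect a step beyond the scatter in either direction, and the expected step from compound 3 to compound 4 is a step that the limit leaves unreadable from compound 3 to compound 4. For compound 4 in this assay the estimate is 20000 nM, within 5000 nM to 100000 nM, with the result most likely reported again only as a limit.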

Compound 4, inhibition constant: > 10000 nM
Compound 4 gave a limit, no number (the forecaster's own chance of this, stated with the estimate: 85%); the middle value lies beyond the limit too.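

Compound 4 also gives only a limit in this assay, so none of its steps from compound 1, compound 2 or compound 3 can be read, since each joins two limits: the limit of > 10000 nM in this assay, at which 4 of the 4 values shown sit.

The compounds shown leave open how strongly any of them inhibits, and whether any other aryl group on the ring nitrogen would yield a measurable number.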